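Swapping tert-butyl for diethylamino on a shared amide core

This account rests on a few compounds, and the source may have more. Where it says the series, first, only, none or still open, it means among the compounds named here.

Of the compounds shown here, three sharing one amide core have been tested in a functional assay on the whole organism (integument) for inhibition, with Chilo suppressalis as the target, read by scintillation counting, with a stated time of 72 h; on this read-out lower numbers stand for stronger inhibition and higher numbers for weaker inhibition. Compound 1 `O=C(Nc1nnc(-c2ccc(Cl)cc2)s1)c1c(F)cccc1F` reaches only the limit of this assay, > 5010 nM, which means that no number was obtained for it (the limit of > 5010 nM in this assay, at which 1 of the 3 values shown sits). Compound 2 `Cc1cccc(C)c1C(=O)Nc1nnc(-c2ccc(Cl)cc2)s1` gives 69.2 nM in this assay. Compound 3 `COc1cccc(OC)c1C(=O)Nc1nnc(-c2ccc(C(C)(C)C)cc2)s1` gives 912 nM in this assay, the highest of the two numbers recorded, and its nearest neighbour is compound 2, whose number is lower by a gap that lies beyond the scatter of repeated measurements.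

Compound 4 `CCN(CC)c1ccc(-c2nnc(NC(=O)c3c(OC)cccc3OC)s2)cc1` has not yet been measured in this assay. It differs from compound 3 in one place: diethylamino in place of tert-butyl on an aromatic carbon. Within the data shown here, no measured pair in the set shows the effect of such a change, so the expectation rests on compound 3 alone. The step from compound 3 to compound 4 in this assay is expected to be small, within the scatter, a 1.3-fold higher number from compound 3 to compound 4 (0.12 log units; within the scatter). Compound 4 is therefore estimated at 1200 nM, between 300 nM and 5000 nM.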

Compound 4, half-maximal inhibitory concentration: 741 nM
Compound 4: middle estimate off by 1.6-fold (0.21 log units), on the high side, within the range that was stated.
By their numbers in this assay, from the lowest: compound 2; then compounds 4 and 3 (each within the scatter of the next). At a limit, above all of these: compound 1.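

Among these compounds, the exchange of tert-butyl for diethylamino gives the first measured step at this position in this assay: a 1.2-fold lower number from compound 3 to compound 4 (0.09 log units; within the scatter). On this aromatic carbon, para to a large group, diethylamino therefore brings in a nitrogen and a hydrogen-bond acceptor that tert-butyl lacks, yet the read-out does not separate the two compounds. Nothing in the data shown accounts for this outcome.

On these data alone, it remains open whether a primary amine, a carboxylic acid or a longer alkyl chain on this same carbon would also leave the read-out within the scatter. Equally open, as far as these compounds go, is whether diethylamino would behave the same way in the setting of compound 2, which gives 69.2 nM and differs from compound 3 in more than one place.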